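Ester variation on a hydroxy-amide acrylate series

This account rests on a few compounds, and the source may have more. Where it says the series, first, only, none or still open, it means among the compounds named here.

Measured so far:
compound 2, `CCOC(=O)/C=C/NC(=O)[C@H](O)C(C)(C)CO`: 36%
compound 3, `CC(C)(CO)[C@H](O)C(=O)N/C=C/C(=O)OCc1ccccc1`: 19%
compound 1, `COC(=O)/C=C\NC(=O)[C@H](O)C(C)(C)CO`: "not determined" (no result reported)

Compound 1 is the methyl ester of the series. In an ADME assay on WI-38 cells (Homo sapiens) for inhibition, read by CellTiter-Glo, with a stated time of 48 h, tested at 100 uM (a higher number here means more inhibition at the concentration tested (going by the name of the read-out), a lower number less inhibition), compound 1 stands as "not determined" (no result reported); no number was reported for it, so its position within the series rests on nothing measured. The two esters that were read give a picture of the level at which the set sits: in this assay compound 2 gives 36%, and in this assay compound 3 gives 19%. Within the data shown here, these two values are all that the series shows, and no single step between them is recorded, so they are taken only as two points of reference for the shared core of compound 1.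

Compound 4, `CC(C)(C)OC(=O)/C=C\NC(=O)[C@H](O)C(C)(C)CO`, is the next ester. It differs from compound 1 by tert-butyl in place of methyl on an oxygen next to a carbonyl group. Among the measured compounds shown here, no step between measured compounds exists for this change, so its size cannot be read from the data. Compound 2 and compound 3 carry other groups on the same oxygen and both sit in the lower to middle range of inhibition, which makes a result of similar size the plain expectation for compound 4, with no direction beyond the scatter assumed. Compound 4 is therefore estimated at 25%, within 5% to 50%.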

Compound 4, a percentage reported as inhibition, at one concentration (the size of the read-out at that concentration, not a potency): -14%
Estimate against measurement, compound 4: 39 percentage points above; measured number below the stated range.
By their numbers in this assay, from the lowest: compound 4; then compound 3; then compound 2.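

In this assay no new step can be read that links compound 4 to compound 1, compound 2 or compound 3. The compounds shown leave open how far the change from methyl to tert-butyl, taken alone, moves the read-out on the shared core. Nothing at hand bears on the result for compound 4.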